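Carbamate oxygen substituents and acid dissociation in the series

The source may hold more compounds than are shown below. What is called first, only, known or untested is meant among the compounds shown, and "the series" means these compounds.

Measured compounds:
- compound 1, `CCOC(=O)COC(=O)NCCCC(C)Nc1cc(OC)cc2cccnc12`, a physicochemical assay for acid dissociation: 12.9
- compound 2, `CCOC(=O)NCCCC(C)Nc1cc(OC)cc2cccnc12`, this assay: 15.9
- compound 3, `COc1cc(NC(C)CCCNC(=O)Oc2ccccc2)c2ncccc2c1`, this assay: 9.95

Compound 3 stands lowest of the three numbers; its nearest neighbour is compound 1 and its furthest is compound 2, both beyond the scatter. All three share one core and differ only in the group on the oxygen next to the carbonyl group, so every measured step bears on that position. Going from compound 1 to compound 2 the number rose, a number 3.00 log units higher from compound 1 to compound 2 (beyond the scatter); from compound 1 to compound 3 it fell, a number 2.95 log units lower from compound 1 to compound 3 (beyond the scatter); from compound 2 to compound 3 it fell further, a number 5.95 log units lower from compound 2 to compound 3 (beyond the scatter).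

Compound 4, `COc1cc(NC(C)CCCNC(=O)OCC(F)(F)F)c2ncccc2c1`, is not yet measured. It differs from compound 3 as follows: 2,2,2-trifluoroethyl in place of phenyl on an oxygen next to a carbonyl group. The two steps that end at compound 3 both show the phenyl group at this oxygen giving the lowest number of the three, with the saturated chain groups well above it. A reversal of that kind, from phenyl back to a saturated chain, is therefore expected to move the number up, with a step estimated at a number 2.85 log units higher from compound 3 to compound 4 (beyond the scatter). Compound 4 is expected to land near the middle of the three measured values, at 12.8 with a range from 11.5 to 14.5.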

Compound 4, acid dissociation constant: 12.4
For compound 4 the middle estimate is 0.40 log units above the measured one; the measured number falls inside the stated range.
By their numbers in this assay, from the lowest: compound 3; then compound 4; then compound 1; then compound 2.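

In this assay, exchanging phenyl for 2,2,2-trifluoroethyl on the oxygen next to a carbonyl group gives [ a number 2.45 log units higher from compound 3 to compound 4 (beyond the scatter) ], so phenyl stays lowest among the four groups at this oxygen, and a saturated chain group there need not reach the level of ethyl. The saturated chain carbon bound to this oxygen proves to be a sensitive site in its own right: trifluoromethyl in place of methyl gives [ a number 3.50 log units lower from compound 2 to compound 4 (beyond the scatter) ], a large step from a change on that one carbon. Trifluoromethyl in place of ethoxycarbonyl on the same carbon gives only [ a number 0.50 log units lower from compound 1 to compound 4 (beyond the scatter) ], a modest step though still beyond the scatter, so these two groups leave the number much closer together than methyl and trifluoromethyl do.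

The compounds shown leave open how the number behaves with a single fluorine or two fluorines on that carbon, with an amine or a carboxylic acid there, or with a longer chain. They also leave open whether a fluorine or a methoxy group on the phenyl ring would move compound 3 further from the saturated chain groups. Nothing available here explains the size of these steps.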